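The compounds below may be only part of what the source reports. "The series", "measured", "known", "first", "only" and "open" are said of these compounds alone.

Working notes on the series

Going by the values given here, compound 2 `Cc1nn(C)c(-n2cccn2)c1/C=N/OCc1ccc(C(=O)OC(C)(C)C)cc1` holds the lowest number of the two measured so far. In a functional assay on A549 cells (Homo sapiens) for cytotoxicity (on this read-out lower numbers stand for stronger inhibition and higher numbers for weaker inhibition), compound 2 gives 2.49 ug/mL. Its nearest neighbour is compound 1 `Cc1nn(C)c(-n2ccnc2)c1/C=N/OCc1ccc(C(=O)OC(C)(C)C)cc1`, which in this assay gives 5.93 ug/mL. Among the compounds with values here, the one measured step, a 2.4-fold lower number from compound 1 to compound 2 (0.38 log units; beyond the scatter), is the only step in the set, and it concerns an exchange of one five-membered nitrogen ring for another on the aromatic carbon of the shared core.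

Compound 3 `Cc1nn(C)c(Sc2ccccc2)c1/C=N/OCc1ccc(C(=O)OC(C)(C)C)cc1` is not yet measured. It differs from compound 2 by phenylsulfanyl in place of 1H-pyrazol-1-yl on an aromatic carbon. Within the data shown here, no measured step exchanges a five-membered nitrogen ring for a sulfur-linked carbon ring, so the step from compound 1 to compound 2 bears on this change only in that it shows a modest shift at the same position, with the group that enters here differing far more from what leaves than it did there.

For compound 3 no step beyond the scatter is expected in either direction, given the absence of any comparable change, so its number in this assay is estimated at 2.6 ug/mL with a range from 1 ug/mL to 7 ug/mL, meaning an expected step of a 1.0-fold higher number from compound 2 to compound 3 (0.02 log units; within the scatter).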

Compound 3, half-maximal inhibitory concentration: 0.13 ug/mL
The estimate for compound 3 lay 20-fold (1.30 log units) above the measured number; the measured number lies below the stated range.
By their numbers in this assay, from the lowest: compound 3; then compound 2; then compound 1.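

In this assay this position, on an aromatic carbon of the shared core, proves able to carry a far larger change than the exchange between the two five-membered nitrogen rings showed: phenylsulfanyl in place of 1H-pyrazol-1-yl gives a 19-fold lower number from compound 2 to compound 3 (1.28 log units; beyond the scatter) and phenylsulfanyl in place of 1H-imidazol-1-yl gives a 46-fold lower number from compound 1 to compound 3 (1.66 log units; beyond the scatter) as the widest step in the set. Both nitrogen rings therefore stand well apart from the sulfur-linked carbon ring on this read-out, while the step between the two rings themselves remains modest at a 2.4-fold lower number from compound 1 to compound 2 (0.38 log units; beyond the scatter) and is the smaller of the three. No measurement at hand bears on what lies behind the large steps.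

The compounds shown do not separate the contribution of the sulfur link from that of the phenyl ring, and a phenoxy, anilino or benzyl group at this position would be needed to tell them apart. Also open, going by these compounds, is whether the step holds with a chloro or methoxy group on the phenyl ring, or with a carboxylic acid in place of the tert-butyl ester at the far end of the shared core.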